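Para-substituent swap on the benzylidene arm of the semicarbazone series

The source may report more compounds than this note shows. Statements on the series, on what has been measured and on what is new or still open speak of the compounds shown alone.

Three semicarbazones sharing one core have been measured in a functional assay on A549 cells (Homo sapiens) for antiproliferative activity, read by MTT assay, with a stated time of 72 h; on this read-out lower numbers stand for stronger inhibition and higher numbers for weaker inhibition. Compound 1 `O=C(N/N=C/c1ccc(Br)cc1)Nc1ccc(Oc2ccnc3[nH]ccc23)c(F)c1` gives 820 nM, the lowest of the three numbers, though the gap to compound 2 lies within the scatter. Compound 2 `N#Cc1ccc(/C=N/NC(=O)Nc2ccc(Oc3ccnc4[nH]ccc34)c(F)c2)cc1` gives 1360 nM, and compound 3 `O=C(N/N=C/c1ccc(Cl)c(Cl)c1)Nc1ccc(Oc2ccnc3[nH]ccc23)c(F)c1` gives 2650 nM. The step from compound 1 to compound 2, a 1.7-fold higher number from compound 1 to compound 2 (0.22 log units; within the scatter), is a swap of one substituent on the same aromatic carbon; the step to compound 3, a 3.2-fold higher number from compound 1 to compound 3 (0.51 log units; beyond the scatter), changes the substitution pattern of the whole ring; a 1.9-fold higher number from compound 2 to compound 3 (0.29 log units; within the scatter) is within the scatter.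

Compound 4 `COc1ccc(/C=N/NC(=O)Nc2ccc(Oc3ccnc4[nH]ccc34)c(F)c2)cc1` differs from compound 1 by methoxy in place of bromo on an aromatic carbon. Going by the values given here, no measured step introduces a methoxy, so only the substituent swap from compound 1 to compound 2, a 1.7-fold higher number from compound 1 to compound 2 (0.22 log units; within the scatter), bears on it, and that swap stayed within the scatter. A step of similar size, a small rise if any, is therefore expected, a 1.5-fold higher number from compound 1 to compound 4 (0.17 log units; within the scatter). Compound 4 is expected to give about 1200 nM in this assay, with a range from 500 nM to 3000 nM.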

Compound 4, half-maximal inhibitory concentration: 3980 nM
Compound 4: middle estimate off by 3.3-fold (0.52 log units), on the low side; measured number above the stated range.
By their numbers in this assay, from the lowest: compounds 1, 2, 3 and 4 (each within the scatter of the next, the first and the last beyond it).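

Notes on this position: in this assay, the site para to a large group proves sensitive to a single-substituent swap, which the bromo-to-cyano step alone did not show. Methoxy in place of bromo gives a 4.9-fold higher number from compound 1 to compound 4 (0.69 log units; beyond the scatter), and methoxy in place of cyano gives a 2.9-fold higher number from compound 2 to compound 4 (0.47 log units; beyond the scatter). The 4-methoxyphenyl arm is not separated from the 3,4-dichlorophenyl arm, with a 1.5-fold higher number from compound 3 to compound 4 (0.18 log units; within the scatter), and nothing available here accounts for the loss seen with methoxy.

Still open, from the compounds shown here alone, is how a hydroxy, an amine or a longer chain such as ethoxy would read at this position relative to bromo. Also open, going by these compounds, is whether the methoxy result depends on the oxygen or on the whole group, which a methyl group at the same carbon could begin to address.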